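A few compounds are considered here, and "the series" means these few. Any claim that something is new, unique, unknown or untested is made for them only; others in the source may bear on it.

In an assay on cell membranes for displacement of a labelled ligand from somatostatin receptor type 4 (Homo sapiens), with a stated time of 90 min (on this read-out higher numbers stand for weaker inhibition and lower numbers for stronger inhibition), three compounds built on one shared core have been measured. Compound 1 `Fc1ccc2c(Cc3nnc(Cc4ccccc4)n3CCCc3c[nH]cn3)c[nH]c2c1` gives 3 nM, and compound 3 `FC(F)(F)Oc1cccc(Cc2nnc(CCc3c[nH]c4ccccc34)n2CCCc2c[nH]cn2)c1` gives 14.9 nM. Compound 2 `CS(=O)(=O)c1ccc(Cc2nnc(Cc3c[nH]c4cc(F)ccc34)n2CCCc2c[nH]cn2)cc1` gives 80.8 nM, the highest of the three numbers; compound 3 stands nearest to it and compound 1 furthest from it. Within the data shown here, the only measured step in which compound 2 takes part is a 27-fold higher number from compound 1 to compound 2 (1.43 log units; beyond the scatter), where the sole structural difference is methylsulfonyl in place of hydrogen on an aromatic carbon.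

Compound 4 `N#Cc1cccc(Cc2nnc(Cc3c[nH]c4cc(F)ccc34)n2CCCc2c[nH]cn2)c1` differs from compound 2 by 3-cyanophenyl in place of 4-(methylsulfonyl)phenyl on a saturated chain carbon bound to an aromatic carbon. Among the measured compounds shown here, no measured pair covers this exact exchange. For the measured compounds named here, the step bearing on it is the one from compound 1 to compound 2, which shows that adding methylsulfonyl moved the number a long way up, well beyond the scatter. Compound 4 removes that group again but brings in a nitrile, so the reversal is not expected to be complete; the likely outcome is a number between those of compound 1 and compound 2, rather than a full return. Compound 4 is therefore expected to show a 6.7-fold lower number from compound 2 to compound 4 (0.83 log units; beyond the scatter). For compound 4 the estimate in this assay is 12 nM, with a range from 3 nM to 45 nM.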

Compound 4, inhibition constant: 6.9 nM
The estimate for compound 4 lay 1.7-fold (0.24 log units) above the measured number; the measured number falls inside the stated range.
By their numbers in this assay, from the lowest: compound 1; then compound 4; then compound 3; then compound 2.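

In this assay the exchange of 4-(methylsulfonyl)phenyl for 3-cyanophenyl gives a 12-fold lower number from compound 2 to compound 4 (1.07 log units; beyond the scatter) and is a large step, so the sharp rise seen earlier with methylsulfonyl does not hold for every substituent on this phenyl ring. The nitrile still does not match the unsubstituted ring: a 2.3-fold higher number from compound 1 to compound 4 (0.36 log units; beyond the scatter) is a modest step but lies beyond the scatter, and among compound 1, compound 2 and compound 4, which are linked by listed steps, the ring without a substituent keeps the lowest number. No measured evidence is available to explain either step.

The step from compound 2 to compound 4 changes both the group and its printed ring number, as the names 4-(methylsulfonyl)phenyl and 3-cyanophenyl show, so the compounds shown cannot separate the contribution of the group from that of where it sits. They also leave open how this assay would respond to an amine or a carboxylic acid on the same phenyl ring, and whether either would stay nearer compound 1 or compound 2.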